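Swapping Chloro for Methoxy in a Small Series

This account rests on a few compounds, and the source may have more. Where it says the series, first, only, none or still open, it means among the compounds named here.

In a functional assay on A549 cells (Homo sapiens) for inhibition, read by MTT assay, with a stated time of 48 h (on this read-out higher numbers stand for weaker inhibition and lower numbers for stronger inhibition), compound 1 `Nc1n[nH]c2cccc(-c3cccc(NC(=O)Nc4ccc(F)c(F)c4)c3)c12` gives 3040 nM and compound 2 `Nc1n[nH]c2cccc(-c3cccc(NC(=O)Nc4cccc(Cl)c4)c3)c12` gives 1720 nM. Within the data shown here, these are the only two measured numbers, and the change between them is a 1.8-fold lower number from compound 1 to compound 2 (0.25 log units; within the scatter). Compound 2 therefore cannot be told apart from compound 1 on these data.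

Compound 3 `COc1cccc(NC(=O)Nc2cccc(-c3cccc4[nH]nc(N)c34)c2)c1` keeps the structure of compound 2 except for one group: methoxy in place of chloro on an aromatic carbon. Put simply, methoxy takes the place of chloro on an aromatic carbon, meta to a large group.

Among the measured compounds shown here, only one measured step bears on this, and it is an indirect guide. For the measured compounds named here, the step of a 1.8-fold lower number from compound 1 to compound 2 (0.25 log units; within the scatter) also alters the groups on an aromatic ring, but it is a different exchange, and no measured compound carries methoxy. Two compounds show no trend, so the expectation is for no shift beyond the scatter, with a wide range to reflect how little is known. The estimate amounts to a 1.3-fold higher number from compound 2 to compound 3 (0.11 log units; within the scatter), an expected step that stays within the scatter. For compound 3 the expected value in this assay is 2200 nM, with an estimated range of 900 nM to 5500 nM.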

Compound 3, half-maximal inhibitory concentration: 2490 nM
Compound 3: the middle estimate sits 1.1-fold (0.05 log units) below what was measured, within the range that was stated.
By their numbers in this assay, from the lowest: compounds 2, 3 and 1 (each within the scatter of the next).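

In this assay this position accepts a real change of group: methoxy, with 2 heavy atoms and 1 hydrogen-bond acceptor, replaces chloro, with 1 heavy atom and 0 hydrogen-bond acceptors, on an aromatic carbon, meta to a large group, and the result is a 1.4-fold higher number from compound 2 to compound 3 (0.16 log units; within the scatter) and so no measurable difference. The comparison of whole rings on the amide-type nitrogen reads the same way, with 3-methoxyphenyl in place of 3,4-difluorophenyl giving a 1.2-fold lower number from compound 1 to compound 3 (0.09 log units; within the scatter), so compounds 1, 2 and 3 cannot be told apart and the three rings show no trend. No separate measurement is available that could explain these numbers.

Still open, as far as these compounds go, is whether a hydroxyl, an amine, a carboxylic acid or a longer chain such as ethoxy in the same place would also stay within the scatter, or would finally shift the number clearly in either direction. Also open, from the compounds shown here alone, is whether methoxy would behave the same way at other carbons of this ring, since all the comparisons here concern only a few groups on a single shared core.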